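The compounds below may be only part of what the source reports. "The series", "measured", "known", "first", "only" and "open" are said of these compounds alone.

In a functional assay on HT-29 cells (Homo sapiens) for antiproliferative activity, read by sulforhodamine B assay, with a stated time of 48 h (a lower number here means a stronger inhibitor, a higher number a weaker inhibitor), three compounds sharing one core and differing in the group on an oxygen have been measured. Compound 3 `CN1CCN(c2ccc(S(=O)(=O)Oc3cccc(I)c3)cc2)C1=O` gives 590 nM, the lowest of the numbers, and the nearest, compound 1 `Cc1ccc(OS(=O)(=O)c2ccc(N3CCN(C)C3=O)cc2)c(C)c1`, gives 3000 nM. Compound 2 `CN1CCN(c2ccc(S(=O)(=O)Oc3cccc(F)c3)cc2)C1=O` gives > 100000 nM, which is a limit of the assay and not a number.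

The next compound is compound 4 `Cc1ccc(OS(=O)(=O)c2ccc(N3CCN(C)C3=O)cc2)cc1`, with 4-methylphenyl in place of 3-iodophenyl on an oxygen. All three measured steps change this same group, so all bear on it. The swings with compound 2 are large: an at least 33-fold higher number from compound 1 to compound 2 (1.52 log units; beyond the scatter) and an at least 160-fold lower number from compound 2 to compound 3 (2.22 log units; beyond the scatter). The step between the two compounds with actual numbers is modest: a 5.1-fold lower number from compound 1 to compound 3 (0.71 log units; beyond the scatter). Compound 4 has no halogen, and its 4-methylphenyl resembles the 2,4-dimethylphenyl of compound 1, so compound 1 at 3000 nM is the closest guide. Compound 2 still warns that a small change in this group can cost far more. A modest rise rather than a large one is therefore expected, and the estimate is a 6.8-fold higher number from compound 3 to compound 4 (0.83 log units; beyond the scatter). Compound 4 is expected at 4000 nM, with an estimated range from 800 nM to 25000 nM.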

Compound 4, half-maximal inhibitory concentration: > 100000 nM
Compound 4 ended at the assay's limit; the forecaster's own chance of this, stated with the estimate: 10%; at least 25-fold (1.39 log units) between middle value and limit.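

Removing one methyl from the 2,4-dimethylphenyl of compound 1 gives an at least 33-fold higher number from compound 1 to compound 4 (1.52 log units; beyond the scatter), so a single methyl on this aromatic ring can decide whether a number can be read at all. The change from 3-iodophenyl to 4-methylphenyl gives an at least 160-fold higher number from compound 3 to compound 4 (2.22 log units; beyond the scatter), and of the four compounds, only the 2,4-dimethylphenyl group of compound 1 and the 3-iodophenyl group of compound 3 give actual numbers, so neither a halogen nor a methyl on the ring is enough in itself, as compound 2 with its fluoro and compound 4 with its methyl both show. The step from compound 2 to compound 4 cannot be read, and neither compound can be ranked against the other, as each value is only a limit of the assay: the limit of > 100000 nM in this assay, at which 2 of the 4 values shown sit.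

The compounds shown leave open whether 3-chlorophenyl or 3-bromophenyl would give numbers closer to that of the 3-iodophenyl or to the limit reached with the 3-fluorophenyl. They also leave open how 2-methylphenyl alone, or a ring carrying an amine or a carboxylic acid, would behave on this oxygen.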